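A few compounds are considered here, and "the series" means these few. Any claim that something is new, unique, unknown or untested is made for them only; others in the source may bear on it.

In a functional assay on MDA-MB-231 cells (Homo sapiens) for antiproliferative activity, read by MTT assay, with a stated time of 72 h (a higher number here means a weaker inhibitor, a lower number a stronger inhibitor), three compounds have been measured:

Compound 1 `O=C(CCc1cccc2c1B(O)OC2)Nc1ccccc1`: 230 nM
Compound 2 `O=C(CCc1cccc2c1B(O)OC2)Nc1ccc(F)cc1`: 440 nM
Compound 3 `O=C(CCc1cccc2c1B(O)OC2)Nc1cccc(-c2ccccc2)c1`: 220 nM

Compound 2 differs from compound 1 by fluoro in place of hydrogen on an aromatic carbon, and that change gave a 1.9-fold higher number from compound 1 to compound 2 (0.28 log units; within the scatter). Compound 3 differs from compound 1 by phenyl in place of hydrogen on an aromatic carbon, a change that gave a 1.0-fold lower number from compound 1 to compound 3 (0.02 log units; within the scatter), so the two values stand together and no order between them can be read. Compound 4 `O=C(CCc1cccc2c1B(O)OC2)Nc1cccc(-c2cccc(F)c2)c1` has not yet been measured; it differs from compound 3 by fluoro in place of hydrogen on an aromatic carbon. Going by the values given here, this is the same kind of change as the one from compound 1 to compound 2, but not the same: there the fluoro enters para to a large group, here it enters meta to a large group. Resting on the step from compound 1 to compound 2, which gave a 1.9-fold higher number from compound 1 to compound 2 (0.28 log units; within the scatter), an expected step of a 1.5-fold higher number from compound 3 to compound 4 (0.16 log units; within the scatter) seems reasonable for compound 4, a small shift that may well fall inside the scatter. Compound 4 is therefore estimated at 320 nM, with a likely range from 150 nM to 700 nM.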

Compound 4, half-maximal inhibitory concentration: 570 nM
Beside the measured number, compound 4's estimate is 1.8-fold (0.25 log units) below it; low and high end bracket the measured number.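

In this assay, fluoro in place of hydrogen on an aromatic carbon gave a 2.6-fold higher number from compound 3 to compound 4 (0.41 log units; beyond the scatter), and the whole 3-fluorophenyl in place of hydrogen gave a 2.5-fold higher number from compound 1 to compound 4 (0.39 log units; beyond the scatter). Set beside the earlier fluoro step, the change carries from one core to the other in the same direction, and the two sizes cannot be told apart: the same change on two cores in this assay, a 1.9-fold higher number (0.28 log units; within the scatter) from compound 1 to compound 2 and a 2.6-fold higher number (0.41 log units; beyond the scatter) from compound 3 to compound 4, 1.4-fold (0.13 log units) apart, within the scatter of two such steps This rests on only two pairs, one per core, with the fluoro entering at a different place in each and the earlier step alone lying within the scatter, so it does not show a rule for other cores or a reason for the shift.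

The compounds shown leave open whether chloro, methoxy or a nitrile in place of the fluoro would follow the same step. They also leave open how a longer chain in place of the one leading to the amide carbonyl would affect the series.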